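Replacing methyl with hydroxy on a saturated ring carbon

This account rests on a few compounds, and the source may have more. Where it says the series, first, only, none or still open, it means among the compounds named here.

In an ADME assay on microsomes from liver (Homo sapiens) for metabolic stability, with a stated time of 10 min (a higher number here means that more of the compound is left, a lower number that less of the compound is left), compound 1 (`NC(=O)[C@H]1CC[C@H](C(=O)N2CC[C@](c3ccc(C(F)(C(F)(F)F)C(F)(F)F)cc3)(S(=O)(=O)c3ccc(F)cc3)C2)CC1`) gives 100%. Compound 2 (`CC1(C(=O)N2CC[C@](c3ccc(C(F)(C(F)(F)F)C(F)(F)F)cc3)(S(=O)(=O)c3ccc(F)cc3)C2)CCS(=O)(=O)CC1`) has no single number, its result standing as "not determined" (no result reported). Compound 3 (`O=C(N1CC[C@](c2ccc(C(F)(C(F)(F)F)C(F)(F)F)cc2)(S(=O)(=O)c2ccc(F)cc2)C1)C1(O)CCS(=O)(=O)CC1`) remains unmeasured. The structural change is hydroxy in place of methyl on a saturated ring carbon, with hydroxy in place of methyl on a saturated ring carbon, three ring bonds from the ring sulfur. For the measured compounds named here, no measured step can size this change, so only a tentative expectation is possible: no shift beyond the scatter. That expectation leans on compound 1, which shares the core and gives 100%. Compound 3 is expected at 90%, with an estimated range of 70% to 100%.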

Compound 3, percent of the compound remaining: 100%
Compound 3: the middle estimate sits 10 percentage points below what was measured; the measured number falls inside the stated range.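

In this assay the 4-hydroxy-1,1-dioxothian-4-yl group on the carbonyl carbon, in place of 4-carbamoylcyclohexyl, gives no change at the digits printed from compound 1 to compound 3 (within the scatter), the first readable result for a group of this kind at this position. The step from compound 2 to compound 3 cannot be read, as compound 2 has no number. No evidence at hand accounts for this result. The compounds shown leave open how methyl and hydroxy compare directly on this ring carbon. They also leave open whether an amine or a carboxylic acid there would read the same in this assay.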